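The compounds below may be only part of what the source reports. "The series", "measured", "known", "first", "only" and "open" are said of these compounds alone.

Compound 1 `C=C1C(=O)O[C@H]2[C@H]1CC/C(COC(=O)Cn1cc(F)c(=O)[nH]c1=O)=C\CC[C@@]1(C)O[C@@H]21`: > 20000 nM
Compound 2 `C=C1C(=O)O[C@H]2[C@H]1CC/C(Cn1cc(Cn3cc(F)c(=O)[nH]c3=O)nn1)=C\CC[C@@]1(C)O[C@@H]21`: > 20000 nM
Compound 3 `C=C1C(=O)O[C@H]2[C@H]1CC/C(COC(=O)Cn1cc(F)c(=O)n(Cc3ccc(Cl)cc3)c1=O)=C\CC[C@@]1(C)O[C@@H]21`: 2560 nM

All three were tested in a functional assay on Bel-7402 cells (Homo sapiens) for antiproliferative activity, read by MTT assay, with a stated time of 72 h; a higher number here means a weaker inhibitor, a lower number a stronger inhibitor. The value for compound 1 is a limit of the assay. The value for compound 2 is also a limit. Compound 3 alone has an actual number, 2560 nM.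

Compound 4 `C=C1C(=O)O[C@H]2[C@H]1CC/C(COC(=O)Cn1cc(F)c(=O)n(Cc3cccc(F)c3)c1=O)=C\CC[C@@]1(C)O[C@@H]21` keeps the core of compound 3 but swaps 4-chlorobenzyl for 3-fluorobenzyl: 3-fluorophenyl in place of 4-chlorophenyl on a saturated chain carbon bound to an aromatic nitrogen. Going by the values given here, the one measured step that bears on this is an at least 7.8-fold lower number from compound 1 to compound 3 (0.89 log units; beyond the scatter), which came with 4-chlorobenzyl in place of hydrogen on an aromatic nitrogen. Among the compounds with values here, no measured pair exchanges one benzyl group for another, so only a small change is expected. The expected step is a 1.2-fold higher number from compound 3 to compound 4 (0.07 log units; within the scatter), within the usual scatter. For compound 4 the estimate is 3000 nM, with an expected range of 1200 nM to 9000 nM.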

Compound 4, half-maximal inhibitory concentration: 2530 nM
Compound 4: middle estimate off by 1.2-fold (0.07 log units), on the high side, and the stated range covers the measured number.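

Replacing 4-chlorophenyl with 3-fluorophenyl on a saturated chain carbon bound to an aromatic nitrogen gives a 1.0-fold lower number from compound 3 to compound 4 (0.01 log units; within the scatter) in this assay, so these two groups cannot be told apart at this place. A second benzyl group in place of the hydrogen on the aromatic nitrogen gives an at least 7.9-fold lower number from compound 1 to compound 4 (0.89 log units; beyond the scatter), so the step seen with 4-chlorobenzyl is not unique to that one group. The figure for compound 1 is a limit of the assay, not a number: the limit of > 20000 nM in this assay, at which 2 of the 4 values shown sit.

The compounds shown leave open whether a benzyl group is needed at all. A plain benzyl without halogen, a methyl or a longer alkyl chain on that nitrogen could each behave differently.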